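The source may hold more compounds than are shown below. What is called first, only, known or untested is meant among the compounds shown, and "the series" means these compounds.

Compound 1 `CCCCCC(=O)C(F)(F)F` is a short-chain trifluoromethyl ketone; in an assay on isolated protein for inhibition of Fatty-acid amide hydrolase 1 (Homo sapiens) (on this read-out lower numbers stand for stronger inhibition and higher numbers for weaker inhibition), compound 1 gives 28900 nM. Compound 2 `O=C(O)c1cccc(CCCCCCC(=O)c2ncc(-c3ccccn3)o2)c1` joins an aromatic acid through a longer chain to a heteroaromatic ketone; in this assay compound 2 gives > 600 nM, which is a limit of the assay rather than a measured number. Compound 3 `CCCCCCCC/C=C\CCCCCCC(=O)c1nc2cccnc2o1` carries a long unsaturated chain on a heteroaromatic ketone; in this assay compound 3 gives 11 nM, the lowest of the two numbers available, and the value of compound 1 sits far higher, well beyond the usual scatter. Compound 4 `CCCCCCCC/C=C\CCCCCCC(=O)c1nc2cnccc2o1` differs from compound 3 only in a group of 9 heavy atoms (6 carbon, 2 nitrogen, 1 oxygen; one five-membered aromatic ring with 2 hetero atoms, one six-membered aromatic ring with 1 hetero atom) in place of a group of 9 heavy atoms (6 carbon, 2 nitrogen, 1 oxygen; one five-membered aromatic ring with 2 hetero atoms, one six-membered aromatic ring with 1 hetero atom), on a carbonyl carbon: the same atoms are present, joined differently. Going by the values given here, no measured step between two compounds in this set resembles this change, so its size cannot be read from the data. The step from compound 3 to compound 4 is expected to be a 1.8-fold higher number from compound 3 to compound 4 (0.26 log units; within the scatter), within the scatter. Compound 4 is therefore estimated to give about 20 nM in this assay, most likely between 5 nM and 80 nM.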

Compound 4, inhibition constant: 7.2 nM
Beside the measured number, compound 4's estimate is 2.8-fold (0.44 log units) above it, within the range that was stated.
By their numbers in this assay, from the lowest: compounds 4 and 3 (each within the scatter of the next); then compound 1.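

Joining the same atoms differently in the group on the carbonyl carbon brings a 1.5-fold lower number from compound 3 to compound 4 (0.18 log units; within the scatter) in this assay and so gives no change that can be told from the scatter. Going by these compounds alone, this is the first step in the set that isolates one place, since compound 1 and compound 2 differ from the others in more than one place, and it shows that these two arrangements of the group read alike while the long unsaturated chain stays fixed. Nothing measured here accounts for why the two arrangements read alike. 

Still open, going by these compounds, is whether a group with other atoms on the carbonyl carbon, such as a ring holding sulfur or a ring carrying an amine, would give a similar number. On these data alone, it is also open whether the two arrangements would still read alike on a shorter saturated chain.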